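The source may hold more compounds than are shown below. What is called first, only, known or untested is meant among the compounds shown, and "the series" means these compounds.

Of the compounds shown here, three have been measured in a functional assay on HCT-116 cells (Homo sapiens) for antiproliferative activity, read by MTT assay, with a stated time of 48 h; on this read-out higher numbers stand for weaker inhibition and lower numbers for stronger inhibition. Compound 1 `COc1ccccc1-n1nncc1CN1C(=O)C2(C(C#N)=C(N)Oc3c2c2nc4ccccc4nc2c2ccccc32)c2ccccc21` reaches only the limit of the assay, reported as > 50000 nM. Compound 2 `CC(=O)Nc1ccc(-n2nncc2CN2C(=O)C3(C(C#N)=C(N)Oc4c3c3nc5ccccc5nc3c3ccccc43)c3ccccc32)cc1` likewise stops at the limit, reported as > 50000 nM. For the measured compounds named here, the one step between measured compounds, a step that the two limits leave unreadable from compound 1 to compound 2, therefore cannot be read, since both of its ends sit at the limit of > 50000 nM in this assay, at which 2 of the 3 values shown sit. Going by the values given here, compound 3 `N#CC1=C(N)Oc2c(N)cc3nc4ccccc4nc3c2C12C(=O)N(Cc1cnnn1-c1cccc(C(F)(F)F)c1)c1ccccc12` is the only compound with a number: in this assay compound 3 gives 18900 nM. Compound 4 `N#CC1=C(N)Oc2c(N)cc3nc4ccccc4nc3c2C12C(=O)N(Cc1cnnn1-c1ccc(Cl)cc1[N+](=O)[O-])c1ccccc12` is not yet measured. The change from compound 3 to compound 4 is 4-chloro-2-nitrophenyl in place of 3-(trifluoromethyl)phenyl on an aromatic nitrogen. No measured step bears on this change; the only step shown is unreadable. The expectation therefore rests on compound 3 alone, and the step of a 1.1-fold higher number from compound 3 to compound 4 (0.02 log units; within the scatter) is estimated to lie within the usual scatter, in no particular direction. Compound 4 is expected to give about 20000 nM in this assay, between 8000 nM and 50000 nM, with a fair chance that only a limit is reported.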

Compound 4, half-maximal inhibitory concentration: 28700 nM
Compound 4: the middle estimate sits 1.4-fold (0.16 log units) below what was measured; the range from low to high includes it.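

For the compounds shown here, this is the first readable step. In this assay, 4-chloro-2-nitrophenyl in place of 3-(trifluoromethyl)phenyl on the aromatic nitrogen gives a 1.5-fold higher number from compound 3 to compound 4 (0.18 log units; within the scatter), so two differently substituted phenyl groups of equal heavy-atom count cannot be told apart at this position, even though only the entering group carries hydrogen-bond acceptors. The only earlier step, from compound 1 to compound 2, cannot be read, as both of its ends are limits and not numbers: the limit of > 50000 nM in this assay, at which 2 of the 4 values shown sit.

The compounds shown leave open whether anything other than a substituted phenyl at this position, such as a linear alkyl chain or a phenyl bearing a carboxylic acid or a primary amine, would move the number beyond the scatter. They also leave open whether a step of this kind would read the same on a different core.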